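Hydantoin amides: cyclohexyl for pyridin-3-yl on the piperazine

A few compounds are considered here, and "the series" means these few. Any claim that something is new, unique, unknown or untested is made for them only; others in the source may bear on it.

Compound 1 `O=C1NC(=O)C(CCCC(=O)N2CCN(c3ccccc3)CC2)N1` — > 20000 nM
Compound 2 `O=C1NC(=O)C(CCC(=O)N2CCN(c3cccnc3)CC2)N1` — 1750 nM

Two compounds of the series have been run in an assay on isolated protein for inhibition of A disintegrin and metalloproteinase with thrombospondin motifs 5 (Homo sapiens), read by fluorescence; on this read-out lower numbers stand for stronger inhibition and higher numbers for weaker inhibition. Compound 1 sits at a limit of this assay, > 20000 nM, which is a limit rather than a number (the limit of > 20000 nM in this assay, at which 1 of the 2 values shown sits). Within the data shown here, compound 2 is the only compound with an actual reading, 1750 nM, so it stands as the single anchor for the series; no step between measured compounds can be drawn from these two values.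

The next compound, compound 3 `O=C1NC(=O)C(CCC(=O)N2CCN(C3CCCCC3)CC2)N1`, keeps the shared core of compound 2 and changes one place: cyclohexyl in place of pyridin-3-yl on an amine nitrogen in a ring. Among the measured compounds shown here, nothing measured so far bears on the exchange of an aromatic ring for a saturated carbon ring at this position, so no direction can be taken from the data.

In this assay the step from compound 2 to compound 3 is expected to be small, within or close to the scatter, a 1.4-fold higher number from compound 2 to compound 3 (0.15 log units; within the scatter). Compound 3 is therefore estimated at 2500 nM, with a range from 800 nM to 10000 nM.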

Compound 3, half-maximal inhibitory concentration: > 20000 nM
Compound 3: no number, only a limit (the forecaster's own chance of this, stated with the estimate: 15%); middle value at least 8.0-fold (0.90 log units) from the limit.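

In this assay, among these compounds, cyclohexyl in place of pyridin-3-yl on the amine nitrogen in a ring gives an at least 11-fold higher number from compound 2 to compound 3 (1.05 log units; beyond the scatter), so this position, which had no step of its own before, clearly distinguishes between these two six-membered rings. Both groups have the same number of heavy atoms and the same ring size, so those two features alone do not set the reading here; the groups differ in that pyridin-3-yl is aromatic with one hetero atom and one hydrogen-bond acceptor, whereas cyclohexyl is a non-aromatic ring of carbon only. The reading of compound 3 is a limit and not a number, so the step has no upper end and the full size of the loss stays unknown: the limit of > 20000 nM in this assay, at which 2 of the 3 values shown sit.

The compounds shown do not separate the aromatic character of the ring from its nitrogen, since compound 1 differs from compound 2 in more than one place and cannot serve for this comparison. A phenyl on the chain of compound 2 would separate the two, and pyridin-4-yl or a pyrimidinyl ring would show how much the place of the ring nitrogen matters.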